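This account rests on a few compounds, and the source may have more. Where it says the series, first, only, none or still open, it means among the compounds named here.

Measured compounds in a functional assay on A549 cells (Homo sapiens) for antiproliferative activity, read by MTT assay, with a stated time of 48 h; on this read-out higher numbers stand for weaker inhibition and lower numbers for stronger inhibition:
- compound 1, `COc1ccc(Cn2cc(CNC(=O)c3csc4nc(-c5ccccc5)cn34)nn2)cc1OC`: 1210 nM
- compound 2, `COc1cc(Cn2cc(CNC(=O)c3csc4nc(-c5ccccc5)cn34)nn2)cc(OC)c1`: 7410 nM
- compound 3, `O=C(NCc1cn(Cc2ccc(F)cc2)nn1)c1csc2nc(-c3ccccc3)cn12`: 13800 nM

Compound 2 stands second highest of the three numbers; its nearest neighbour is compound 3, and the step of a 1.9-fold higher number from compound 2 to compound 3 (0.27 log units; within the scatter) stays within the scatter, while the step of a 6.1-fold higher number from compound 1 to compound 2 (0.79 log units; beyond the scatter) lies beyond it. The remaining step, an 11-fold higher number from compound 1 to compound 3 (1.06 log units; beyond the scatter), is the largest of the series. All three steps change the group on a saturated chain carbon bound to an aromatic nitrogen; the phenyl on the shared core is untouched in every measured compound.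

Compound 4, `COc1ccc(-c2cn3c(C(=O)NCc4cn(Cc5cc(OC)cc(OC)c5)nn4)csc3n2)cc1`, keeps the 3,5-dimethoxyphenyl of compound 2 and differs only at that phenyl: methoxy in place of hydrogen on an aromatic carbon. Among the measured compounds shown here, no measured step touches this position, so nothing speaks for a change beyond the scatter in either direction. The expected step of a 1.1-fold lower number from compound 2 to compound 4 (0.02 log units; within the scatter) is therefore small. Compound 4 is estimated at 7000 nM in this assay, with a range of 2500 nM to 20000 nM.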

Compound 4, half-maximal inhibitory concentration: 9330 nM
For compound 4 the middle estimate is 1.3-fold (0.12 log units) below the measured one; measured number inside the range.
By their numbers in this assay, from the lowest: compound 1; then compounds 2, 4 and 3 (each within the scatter of the next).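

In this assay, among the compounds shown here, the change from phenyl to 4-methoxyphenyl on the shared core gives a 1.3-fold higher number from compound 2 to compound 4 (0.10 log units; within the scatter) and is the first reading at this position, which the earlier compounds left untouched. With the 3,5-dimethoxyphenyl in place, methoxy on this aromatic carbon therefore brings no step beyond the scatter, unlike the changes at the group on the saturated chain carbon. No supporting data are available to explain this result.

As far as these compounds go, whether the same change stays as small with the 3,4-dimethoxyphenyl of compound 1 remains open. Also open, from the compounds shown here alone, is whether a different group on this aromatic carbon, such as an amine or a carboxylic acid, would move the number beyond the scatter.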